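The source may report more compounds than this note shows. Statements on the series, on what has been measured and on what is new or still open speak of the compounds shown alone.

Compound 1, `CCCCCCCCCCCCCc1ccc(NC(=O)Nc2c(C(C)C)cccc2C(C)C)cc1`: 11 nM in an assay on isolated protein for inhibition of acyl-CoA:cholesterol acyltransferase (Oryctolagus cuniculus); a lower number here means a stronger inhibitor, a higher number a weaker inhibitor
Compound 2, `CCCCCCc1ccc(NC(=O)Nc2c(C(C)C)cccc2C(C)C)cc1`: 26 nM in this assay

Only these two compounds have been measured, and compound 2 stands with the higher number of the two, that is, the weaker inhibitor: the change from compound 1 to compound 2 gave a 2.4-fold higher number from compound 1 to compound 2 (0.37 log units; beyond the scatter), a shift that sits beyond the usual scatter of the test.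

Compound 3, `CCc1ccc(NC(=O)Nc2c(C(C)C)cccc2C(C)C)cc1`, has not yet been measured. It differs from compound 2 in one place: hydrogen in place of butyl on a saturated chain carbon, two bonds along the chain from an aromatic carbon. In plain words, the chain on the aromatic ring of the shared core is cut down again, this time from hexyl to ethyl.

Among the measured compounds shown here, only one measured step bears on this. Shortening the same chain from tridecyl to hexyl, from compound 1 to compound 2, gave a 2.4-fold higher number from compound 1 to compound 2 (0.37 log units; beyond the scatter), a modest weakening. Cutting further, to ethyl, is expected to weaken binding again, so the step from compound 2 to compound 3 in this assay is estimated as a 3.8-fold higher number from compound 2 to compound 3 (0.59 log units; beyond the scatter). For compound 3 the expected value in this assay is therefore 100 nM, with a likely range from 30 nM to 400 nM.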

Compound 3, half-maximal inhibitory concentration: 100 nM
The estimate for compound 3 equals the measured number at the digits printed, and the stated range covers the measured number.
By their numbers in this assay, from the lowest: compound 1; then compound 2; then compound 3.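

Going from hexyl to ethyl moved the number in the same direction as the earlier shortening, with a 3.8-fold higher number from compound 2 to compound 3 (0.59 log units; beyond the scatter) in this assay for this second cut, so the weakening continues as this chain on the aromatic ring gets shorter. Taken end to end, replacing the long chain with ethyl gives a 9.1-fold higher number from compound 1 to compound 3 (0.96 log units; beyond the scatter) across the series, and in these three compounds the number rises each time the chain is cut, with none going against that order, while compound 3 still gives a measured 100 nM in this assay even with only ethyl left. Nothing available here explains why the length of this chain matters for inhibition.

Going by these compounds, whether a methyl group or a bare hydrogen in place of ethyl would raise the number further remains open, as does whether a chain longer than tridecyl would lower it again. On these data alone, it is also open whether a chain carrying an amine or a carboxylic acid would follow the same order as these plain carbon chains.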